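Fluoro on the benzyl group of compound 2

The compounds below may be only part of what the source reports. "The series", "measured", "known", "first", "only" and "open" are said of these compounds alone.

In a functional assay on SPCA2 cells (Homo sapiens) for cytotoxicity, read by MTT assay, with a stated time of 2 days (on this read-out lower numbers stand for stronger inhibition and higher numbers for weaker inhibition), compound 2 `c1ccc(CO/N=C2/C(c3c[nH]c4ccccc34)=Nc3ccccc32)cc1` gives 21400 nM. Compound 3 `Cc1ccc(CO/N=C2/C(c3c[nH]c4ccc(Br)cc34)=Nc3ccc(Br)cc32)cc1` gives 15100 nM and compound 1 `O=[N+]([O-])c1ccc2c(c1)/C(=N\O)C(c1c[nH]c3ccc([N+](=O)[O-])cc13)=N2` gives 11200 nM. Among the compounds with values here, compound 2 stands within the scatter of both of the others, so these three numbers set no order among the compounds.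

Compound 4 `Fc1ccc(CO/N=C2/C(c3c[nH]c4ccccc34)=Nc3ccccc32)cc1` is compound 2 with benzyl changed to 4-fluorobenzyl: fluoro in place of hydrogen on an aromatic carbon. In words, this is fluoro in place of hydrogen on an aromatic carbon, para to a large group.

Within the data shown here, no two measured compounds differ in one place only, so the data hold no direct measure of this change. Compound 3 differs from compound 2 in more than one place, yet compound 3 gives 15100 nM, which is within the scatter of compound 2. On that evidence, the single fluoro is expected to produce no step beyond the scatter in this assay, in either direction. The estimated 1.2-fold lower number from compound 2 to compound 4 (0.08 log units; within the scatter) therefore stays small. For compound 4 the expected value is 18000 nM, with an estimated range from 9000 nM to 36000 nM.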

Compound 4, half-maximal inhibitory concentration: 25900 nM
Beside the measured number, compound 4's estimate is 1.4-fold (0.16 log units) below it; the range from low to high includes it.
By their numbers in this assay, from the lowest: compounds 1, 3, 2 and 4 (each within the scatter of the next, the first and the last beyond it).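

Within the data shown here, the first comparison that differs in one place only reads a 1.2-fold higher number from compound 2 to compound 4 (0.08 log units; within the scatter) in this assay when fluoro takes the place of hydrogen on an aromatic carbon, para to a large group. Among these compounds, this position on the benzyl group thus accepts fluoro with no step beyond the scatter, a direct reading that the earlier compounds, which differ from one another in more than one place, could not give. No measured evidence bears on why the step is this small.

On these data alone, whether any group at this position can move the number beyond the scatter remains open, and an amine, a carboxylic acid or a methoxy group on the same aromatic carbon would put a group of a different kind in place of fluoro. Also open, as far as these compounds go, is whether the fluoro step keeps its size on the core of compound 3 or the core of compound 1, since here it is read only on the core of compound 2.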